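Phenyl in Place of Isopropyl: Expected Effect on Compound 4

This account rests on a few compounds, and the source may have more. Where it says the series, first, only, none or still open, it means among the compounds named here.

Measured compounds:
compound 1, `COc1ccc(OC(=O)Nc2ccc([Se]C#N)cc2)cc1`, gives 48400 nM
compound 2, `CC(C)COC(=O)Nc1ccc([Se]C#N)cc1`, gives 49500 nM
compound 3, `N#C[Se]c1ccc(NC(=O)Oc2ccc(Cl)cc2)cc1`, gives 38000 nM

In an ADME assay on BEAS-2B cells (Homo sapiens) for cytotoxicity, read by MTT assay, with a stated time of 72 h (a lower number here means a stronger inhibitor of growth, a higher number a weaker inhibitor of growth), the three numbers sit close together. Compound 2 has the highest of them; its nearest neighbour is compound 1, and its furthest is compound 3, both within the scatter. For the measured compounds named here, the only measured step between single-point changes, a 1.3-fold lower number from compound 1 to compound 3 (0.11 log units; within the scatter), concerns a substituent on an aromatic ring and stays within the scatter.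

The new compound 4, `N#C[Se]c1ccc(NC(=O)OCc2ccccc2)cc1`, differs from compound 2 by phenyl in place of isopropyl on a saturated chain carbon bound to an oxygen next to a carbonyl group. Going by the values given here, no measured step exchanges an alkyl for an aromatic group at this position, so the closest guide is the flatness of the three numbers so far, in which changes at the carbamate oxygen side moved nothing beyond the scatter.

The expected step is therefore a 1.1-fold lower number from compound 2 to compound 4 (0.04 log units; within the scatter), no change beyond the scatter. Compound 4 is estimated at 45000 nM, within a range from 22000 nM to 90000 nM.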

Compound 4, concentration for total growth inhibition: 34400 nM
Compound 4: middle estimate off by 1.3-fold (0.12 log units), on the high side, and the stated range covers the measured number.
By their numbers in this assay, from the lowest: compounds 4, 3, 1 and 2 (each within the scatter of the next).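

In this assay, phenyl in place of isopropyl gives a 1.4-fold lower number from compound 2 to compound 4 (0.16 log units; within the scatter), so this change does not move the number beyond the scatter. For the compounds shown here, the only earlier single-place step concerned a substituent on an aromatic carbon, whereas this one is on a saturated chain carbon bound to an oxygen next to a carbonyl group. Here, going from 3 heavy atoms with no ring to 6 heavy atoms in one six-membered aromatic ring leaves the read-out within the scatter, and no supporting measurement is available to explain this result.

As far as these compounds go, whether an amine, a carboxylic acid or a longer chain at this position would shift the number beyond the scatter remains open. The compounds shown also leave open whether any change to the shared core would do so.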